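Dimethylpyrimidine ether in place of the trifluoromethyl pyrazole

A few compounds are considered here, and "the series" means these few. Any claim that something is new, unique, unknown or untested is made for them only; others in the source may bear on it.

Within the data shown here, compound 1 `CC(C)[C@H](NC(=O)COc1cccc2ccccc12)C(=O)N[C@@H](CC(=O)O)C(=O)COc1cc(C(F)(F)F)n(C)n1` is the only member of this set with a number in a functional assay on Jurkat cells (Homo sapiens) for inhibition (on this read-out lower numbers stand for stronger inhibition and higher numbers for weaker inhibition), where compound 1 gives 46000 nM. Compound 2 `CC(C)c1cc(OCC(=O)[C@H](CC(=O)O)NC(=O)[C@@H](NC(=O)COc2cccc3ccccc23)C(C)C)no1` reaches only a limit of this assay, > 200000 nM. Compound 3 `CC(C)[C@H](NC(=O)COc1cccc2ccccc12)C(=O)N[C@@H](CC(=O)O)C(=O)CSc1nncn1C` likewise reaches only a limit, > 200000 nM. Two of the three results thus sit at the limit of > 200000 nM in this assay, at which 2 of the 3 values shown sit. The step of an at least 4.3-fold higher number from compound 1 to compound 2 (0.63 log units; beyond the scatter) and the step of an at least 4.3-fold higher number from compound 1 to compound 3 (0.63 log units; beyond the scatter) both weaken inhibition beyond the scatter. Compound 4 `Cc1cc(OCC(=O)[C@H](CC(=O)O)NC(=O)[C@@H](NC(=O)COc2cccc3ccccc23)C(C)C)nc(C)n1` differs from compound 1 by 2,6-dimethylpyrimidin-4-yl in place of 1-methyl-5-(trifluoromethyl)-1H-pyrazol-3-yl on an oxygen on a saturated carbon. Both measured exchanges at this oxygen weakened inhibition, so a weakening step of comparable size is expected for compound 4, a 3.3-fold higher number from compound 1 to compound 4 (0.51 log units; beyond the scatter). Compound 4 is therefore estimated at 150000 nM, with a range from 40000 nM to 600000 nM.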

Compound 4, half-maximal inhibitory concentration: > 200000 nM
Compound 4: only a limit was reported (the forecaster's own chance of this, stated with the estimate: 45%); middle value at least 1.3-fold (0.12 log units) from the limit.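

In this assay compound 4 reaches only a limit, > 200000 nM. The change to a six-membered aromatic ring on this oxygen gives an at least 4.3-fold higher number from compound 1 to compound 4 (0.63 log units; beyond the scatter), so the weakening now extends beyond the five-membered 5-isopropyl-1,2-oxazol-3-yl exchange. Every exchange shown now ends at the same limit, leaving compound 1 alone with a number: the limit of > 200000 nM in this assay, at which 3 of the 4 values shown sit.

The steps among compound 2, compound 3 and compound 4 cannot be read. Still open, on these data alone, is whether the trifluoromethyl group matters on its own, as a 1-methyl-1H-pyrazol-3-yl group on this oxygen would show.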